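The source may hold more compounds than are shown below. What is called first, only, known or untested is meant among the compounds shown, and "the series" means these compounds.

In a functional assay on NCI-H1975 cells (Homo sapiens) for inhibition, with a stated time of 72 h (on this read-out lower numbers stand for stronger inhibition of growth and higher numbers for weaker inhibition of growth), compound 1 (`COC(=O)c1ccc(CN(C)C(=O)c2cc(C(C)C)c(O)cc2O)cc1`) gives 3500 nM. Compound 2 (`CCN(Cc1ccc(C(=O)NO)cc1)C(=O)c1cc(C(C)C)c(O)cc1O`) gives 7000 nM, within the scatter of compound 1, and compound 3 (`CCCN(Cc1ccc(C(=O)NO)cc1)C(=O)c1cc(C(C)C)c(O)cc1O`) gives 23700 nM. Compound 4 (`CC(C)c1cc(C(=O)N(C)Cc2ccc(C(=O)O)cc2)c(O)cc1O`) is compound 1 with hydrogen in place of methyl on an oxygen next to a carbonyl group, methoxycarbonyl to carboxy: hydrogen in place of methyl on an oxygen next to a carbonyl group. For the measured compounds named here, the only measured step, a 3.4-fold higher number from compound 2 to compound 3 (0.53 log units; beyond the scatter), lies at another place, a saturated chain carbon, so it serves only as a guide to size. Going by the values given here, no measured pair covers this change itself. A modest step to a higher number is expected in this assay, with wide uncertainty. The expected step is a 4.3-fold higher number from compound 1 to compound 4 (0.63 log units; beyond the scatter). Compound 4 is estimated at 15000 nM, with an expected range of 4000 nM to 55000 nM.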

Compound 4, concentration for 50% growth inhibition: 30000 nM
The estimate for compound 4 lay 2.0-fold (0.30 log units) below the measured number; measured number inside the range.
By their numbers in this assay, from the lowest: compounds 1 and 2 (each within the scatter of the next); then compounds 3 and 4 (each within the scatter of the next).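

Methoxycarbonyl to carboxy gives in this assay an 8.6-fold higher number from compound 1 to compound 4 (0.93 log units; beyond the scatter) as the first measured step at this oxygen next to a carbonyl group, since the earlier step lay on a saturated chain carbon. Loss of this one methyl is enough to carry the number beyond the scatter, so the ester methyl is not a silent part of compound 1 in this read-out.

Open, going by these compounds, is whether a longer chain on this oxygen, such as ethyl, or a primary amide in place of the ester would hold the number of compound 1. No measurement at hand explains the rise seen with the carboxy group.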